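Weak Inhibitors and an Amide Swap on the Side Chain

The source may report more compounds than this note shows. Statements on the series, on what has been measured and on what is new or still open speak of the compounds shown alone.

Of the compounds shown here, three built on the same core have been tested in a functional assay on MGC-803 cells (Homo sapiens) for cytotoxicity, read by MTT assay, with a stated time of 48 h; a higher number here means a weaker inhibitor, a lower number a stronger inhibitor. Compound 1 `CCNCC(=O)N1N=C(c2cc3ccccc3oc2=O)CC1c1ccccc1` gives 26600 nM there. Compound 2 `O=C(CNC1CC1)N1N=C(c2cc3ccccc3oc2=O)CC1c1ccccc1` is reported in this assay as "not active" (no number reported), and compound 3 `CC1CCCN(CC(=O)N2N=C(c3cc4ccccc4oc3=O)CC2c2ccccc2)C1` is likewise reported as "not active" (no number reported). So compound 3 stands without any number at all; among the three, only compound 1 has a measured potency, and that one is weak. Compound 4 `NC(=O)C1CCN(CC(=O)N2N=C(c3cc4ccccc4oc3=O)CC2c2ccccc2)CC1` is the next compound to be measured. It differs from compound 3 in one place: 4-carbamoylpiperidin-1-yl in place of 3-methylpiperidin-1-yl on a saturated chain carbon bound to a carbonyl carbon. Nothing measured here shows what such a change does to potency, so no size or direction of step can be read from the shown compounds, and the expectation rests mostly on the fact that compound 3 produced no measurable inhibition and that compound 1 was weak. Compound 4 is therefore expected to remain a weak inhibitor, with an estimated value of about 40000 nM in this assay, within a range from 12000 nM to 150000 nM, and with a considerable chance that again no number is obtained.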

Compound 4, half-maximal inhibitory concentration: 21500 nM
The estimate for compound 4 lay 1.9-fold (0.27 log units) above the measured number, within the range that was stated.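

Compound 4 shows that a piperidin-1-yl group on this saturated chain carbon bound to a carbonyl carbon can give a measurable value in this assay, which compound 3 with its 3-methylpiperidin-1-yl group did not; having no number, compound 3 leaves that step unreadable. Exchanging ethylamino for 4-carbamoylpiperidin-1-yl gives a 1.2-fold lower number from compound 1 to compound 4 (0.09 log units; within the scatter), so this much larger change in the group leaves compound 4 indistinguishable from compound 1 in this assay. Nothing available explains why compound 3 and compound 4 gave different outcomes.

Whether the carbamoyl group itself accounts for the measurable value remains open. An unsubstituted piperidin-1-yl group or a 4-carboxypiperidin-1-yl group at this place would help to separate the role of the ring from that of its substituent.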